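A few compounds are considered here, and "the series" means these few. Any claim that something is new, unique, unknown or untested is made for them only; others in the source may bear on it.

Measured compounds:
compound 1, `COc1cc(Cl)cc(-c2nn(-c3cccc(NC(=O)c4ccc(Cl)c(Cl)c4)c3)cc2-c2ccncc2)c1`, which in a functional assay on OVCAR-3 cells (Homo sapiens) for inhibition, read by sulforhodamine B assay, with a stated time of 48 h, tested at 10 uM (on this read-out lower numbers stand for a stronger effect and higher numbers for a weaker effect at the one concentration tested), gives 53.4%
compound 2, `O=C(Nc1cccc(-n2cc(-c3ccncc3)c(-c3cc(O)cc(Cl)c3)n2)c1)Nc1ccc(Cl)c(C(F)(F)F)c1`, which in this assay gives 1.88%

Compound 2 stands at the lower of the two numbers: its nearest neighbour is compound 1, whose number is higher by a margin beyond the scatter. Among the compounds with values here, no step between two measured compounds that differ in one place is available, so the change leading to compound 3, `O=C(Nc1cccc(-n2cc(-c3ccncc3)c(-c3cc(O)cc(Cl)c3)n2)c1)Nc1ccc(Cl)c(Cl)c1`, has no measured precedent here.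

Compound 3 differs from compound 2 in one place: chloro in place of trifluoromethyl on an aromatic carbon. Both groups entering and leaving carry no donors, no acceptors and no charge, and the place on the ring is unchanged. Without a measured step of this kind, the step from compound 2 to compound 3 in this assay is expected to be small, most likely none beyond the scatter, with a slight lean toward a weaker effect. Compound 3 is therefore estimated at 6%, within a range from 0.5% to 30%, a step of a number 4.1 percentage points higher from compound 2 to compound 3 (within the scatter).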

Compound 3, a percentage reported as activity, at one concentration (the size of the read-out at that concentration, not a potency): -47.4%
Compound 3: the middle estimate sits 53.4 percentage points above what was measured; measured number below the stated range.
By their numbers in this assay, from the lowest: compound 3; then compound 2; then compound 1.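

In this assay, chloro in place of trifluoromethyl on this aromatic carbon, ortho to a chloro group, gives a number 49.3 percentage points lower from compound 2 to compound 3 (beyond the scatter), so the read-out responds strongly to a change at this one place, even though neither group carries donors, acceptors or charge. Here the group of one heavy atom goes with the stronger effect and the group of four with the weaker, and compound 3 gives -47.4%, a number below zero. Nothing available offers a measured reason for this step.

With only this one pair, the compounds shown leave open how a bromo, a methyl or a methoxy group would read at this place. They also leave open whether the same exchange would give a step of similar size on a different core.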